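Amide variation on the shared core: methyl to methoxy

A few compounds are considered here, and "the series" means these few. Any claim that something is new, unique, unknown or untested is made for them only; others in the source may bear on it.

Measured compounds:
Compound 1 `CC(C)CCC(=O)Nc1c(C(O)(C(F)(F)F)C(F)(F)F)ccc2ccccc12`: 49 nM in an assay on LtK cells with ATP-sensitive inward rectifier potassium channel 11 (Homo sapiens) as the target; a higher number here means that more compound is needed for the effect, a lower number that less compound is needed
Compound 2 `O=C(Nc1c(C(O)(C(F)(F)F)C(F)(F)F)ccc2ccccc12)c1ccc(Cl)cc1`: 570 nM in this assay
Compound 3 `Cc1ccc(C(=O)Nc2c(C(O)(C(F)(F)F)C(F)(F)F)ccc3ccccc23)cc1`: 76 nM in this assay

Compound 3 gives the second highest of the three numbers. Its nearest neighbour is compound 1, with a 1.6-fold higher number from compound 1 to compound 3 (0.19 log units; within the scatter), a step within the scatter. Its furthest is compound 2, with a 7.5-fold lower number from compound 2 to compound 3 (0.88 log units; beyond the scatter).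

Compound 4 `COc1ccc(C(=O)Nc2c(C(O)(C(F)(F)F)C(F)(F)F)ccc3ccccc23)cc1` arises from compound 3 by methoxy in place of methyl on an aromatic carbon. The change sits at the same place as the chloro-for-methyl difference, where a 7.5-fold lower number from compound 2 to compound 3 (0.88 log units; beyond the scatter) and a 12-fold higher number from compound 1 to compound 2 (1.07 log units; beyond the scatter) were beyond the scatter. Within the data shown here, no step with a methoxy group is available, so the direction rests on those two steps only; a small rise or none beyond the scatter is expected. For compound 4 the estimate in this assay is 120 nM, range 40 nM to 400 nM, meaning an expected step of a 1.6-fold higher number from compound 3 to compound 4 (0.20 log units; within the scatter).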

Compound 4, half-maximal effective concentration: 417 nM
Beside the measured number, compound 4's estimate is 3.5-fold (0.54 log units) below it; measured number outside the range, above it.
By their numbers in this assay, from the lowest: compounds 1 and 3 (each within the scatter of the next); then compounds 4 and 2 (each within the scatter of the next).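

In this assay the aromatic carbon para to a large group does not tolerate every replacement of methyl: methoxy there gives a step beyond the scatter (a 5.5-fold higher number from compound 3 to compound 4 (0.74 log units; beyond the scatter)). Methoxy and chloro stand within the scatter of each other (a 1.4-fold lower number from compound 2 to compound 4 (0.14 log units; within the scatter)), so among the three groups tried here only methyl stays close to the isopentyl amide, and the 4-methoxyphenyl amide does not (an 8.5-fold higher number from compound 1 to compound 4 (0.93 log units; beyond the scatter)). Nothing available here bears on the reason for this difference.

Open, from the compounds shown here alone, is how an amine or a carboxylic acid at this position would compare with methyl. Also open, going by these compounds, is whether a longer chain in place of isopentyl on the carbonyl carbon would hold the number of compound 1.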